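Compound 2 to compound 4: changing the group on sulfur

This account rests on a few compounds, and the source may have more. Where it says the series, first, only, none or still open, it means among the compounds named here.

In a functional assay on MCF7 cells (Homo sapiens) for antiproliferative activity, read by MTT assay, with a stated time of 72 h (on this read-out lower numbers stand for stronger inhibition and higher numbers for weaker inhibition), compound 2 (`C#CCSc1nc(Sc2nncs2)c(C#N)c(-c2cc(OC)c(OC)c(OC)c2)n1`) gives 9820 nM. Compound 1 (`C#CCSc1nc(Sc2nnnn2CCN(C)C)c(C#N)c(-c2ccc(Cl)cc2)n1`) gives 6180 nM, within the scatter of that value. Compound 3 (`C#CCSc1nc(Sc2nnnn2CCN(C)C)c(C#N)c(-c2cccc(Cl)c2)n1`) gives 4120 nM, a lower number that lies beyond the scatter of the value for compound 2.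

Compound 4 (`C#CCSc1nc(Sc2nc(C)cs2)c(C#N)c(-c2cc(OC)c(OC)c(OC)c2)n1`) differs from compound 2 in one place, on a sulfur whose other neighbour is an aromatic carbon: 4-methyl-1,3-thiazol-2-yl in place of 1,3,4-thiadiazol-2-yl on a sulfur.

Among the compounds with values here, the only measured step, a 1.5-fold lower number from compound 1 to compound 3 (0.18 log units; within the scatter), lies within the scatter and falls on an aromatic carbon, not on this sulfur. Within the data shown here, no measured pair isolates a change of the group on this sulfur, so the series offers only indirect guidance. With only a 1.5-fold lower number from compound 1 to compound 3 (0.18 log units; within the scatter) to go on, no step beyond the scatter is expected in this assay, and the data support no firm direction. The expected change is a 1.3-fold lower number from compound 2 to compound 4 (0.12 log units; within the scatter). For compound 4 the estimated value is 7500 nM, with an expected range of 3000 nM to 18000 nM.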

Compound 4, half-maximal inhibitory concentration: > 20000 nM
Compound 4 ended at the assay's limit; the forecaster's own chance of this, stated with the estimate: 5%; middle value at least 2.6-fold (0.42 log units) away from the limit.
By their numbers in this assay, from the lowest: compounds 3, 1 and 2 (each within the scatter of the next, the first and the last beyond it). At a limit, above all of these: compound 4.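

This sulfur now has its first measured single change: in this assay, 4-methyl-1,3-thiazol-2-yl in place of 1,3,4-thiadiazol-2-yl gives an at least 2.0-fold higher number from compound 2 to compound 4 (0.30 log units; that floor lies within the scatter). The direction is toward weaker inhibition, but this step is only a floor, so its true size cannot be read and the floor alone does not take it beyond the scatter. The result for compound 4 is a limit and not a number: the limit of > 20000 nM in this assay, at which 1 of the 4 values shown sits.

The step changes the ring and adds a methyl group together, so the compounds shown do not separate those two parts of the change. From the compounds shown here alone, how 1,3-thiazol-2-yl without the methyl group, or a ring carrying an amine or a carboxylic acid, would read on this sulfur remains open.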